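Four sulfonyl-bearing peroxides and their cytotoxicity on liver cells

The compounds below may be only part of what the source reports. "The series", "measured", "known", "first", "only" and "open" are said of these compounds alone.

Compound 1 `O=S(=O)(CCCCl)N1CCC2(CC1)OOC1(CCCCC1)OO2` was examined in a functional assay on Huh-7 cells (Homo sapiens) for cytotoxicity, read by MTT assay, with a stated time of 72 h; on this read-out lower numbers stand for higher toxicity in this test and higher numbers for lower toxicity in this test. In this assay compound 1 gives only a limit, > 100 ug/mL. Compound 2 `O=S(=O)(CCCCl)N1CCC2(CC1)OOC1(CCCCCC1)OO2` carries the same sulfonyl side chain, but the difference between the two cores is not broken down here. In this assay compound 2 also gives only a limit, > 100 ug/mL. Compound 3 `O=S(=O)(Cc1ccccc1)N1CCC2(CC1)OOC1(CCCCC1)OO2` differs from compound 1 by phenyl in place of 2-chloroethyl on a saturated chain carbon bound to a sulfonyl sulfur. In this assay compound 3 again gives only a limit, > 100 ug/mL. The step that the two limits leave unreadable from compound 1 to compound 3 therefore has no readable size, since the limit of > 100 ug/mL in this assay, at which 3 of the 3 values shown sit, is where every value sits. Compound 4 `O=S(=O)(Cc1ccccc1)N1CCC2(CC1)OOC1(CCCCCC1)OO2` carries the same change on the core of compound 2: phenyl in place of 2-chloroethyl on a saturated chain carbon bound to a sulfonyl sulfur. For compound 4 the expected step is a step that the limit leaves unreadable from compound 2 to compound 4, because a step that the two limits leave unreadable from compound 1 to compound 3 showed no readable movement. Compound 4 is thus estimated at 150 ug/mL, most probably reported once more as a limit.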

Compound 4, half-maximal cytotoxic concentration: > 100 ug/mL
Compound 4 gave a limit, no number; the forecaster's own chance of this, stated with the estimate: 85%; the middle value is on the limit's open side.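

In this assay, among the compounds shown here, compound 4, like compound 2, gives only a limit, so no step between compound 2 and compound 4 can be read: the limit of > 100 ug/mL in this assay, at which 4 of the 4 values shown sit. The compounds shown leave open at what concentration any of them would become toxic to these cells, and whether the side chain or the core would then matter.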